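Swapping acetyl for ethyl on a ring nitrogen

A few compounds are considered here, and "the series" means these few. Any claim that something is new, unique, unknown or untested is made for them only; others in the source may bear on it.

In a functional assay on KG-1 cells (Homo sapiens) for antiproliferative activity, read by CCK-8 assay, with a stated time of 72 h (a lower number here means a stronger inhibitor, a higher number a weaker inhibitor), three compounds have been measured so far:

Compound 1 `CCN1CCN(c2ccc(C(=O)Nc3n[nH]c4cc(-c5c(F)cc(F)c(OC)c5F)ccc34)cc2)CC1`: > 1000 nM
Compound 2 `COc1ccc(F)c(-c2ccc3c(NC(=O)c4ccc(N5CCCN(C)CC5)cc4)n[nH]c3c2)c1F`: 51.5 nM
Compound 3 `COc1ccc(F)c(-c2ccc3c(NC(=O)c4ccc(N5CCN(C(C)=O)CC5)cc4)n[nH]c3c2)c1F`: 595 nM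

The value of compound 1 is a limit of the assay rather than a number (the limit of > 1000 nM in this assay, at which 1 of the 3 values shown sits). Compound 3 holds the highest of the two real numbers, and the step of a 12-fold higher number from compound 2 to compound 3 (1.06 log units; beyond the scatter) was large.

Compound 4 `CCN1CCN(c2ccc(C(=O)Nc3n[nH]c4cc(-c5c(F)ccc(OC)c5F)ccc34)cc2)CC1` differs from compound 3 by ethyl in place of acetyl on an amine nitrogen in a ring. Among the measured compounds shown here, the one measured step that bears on this change, a 12-fold higher number from compound 2 to compound 3 (1.06 log units; beyond the scatter), went from an alkyl group on the ring nitrogen to acetyl and raised the number strongly; compound 4 reverses that kind of change, so a step back down is expected, a 6.0-fold lower number from compound 3 to compound 4 (0.77 log units; beyond the scatter). Compound 1, which carries the same ethyl group on a different aryl ring, gives only a limit (the limit of > 1000 nM in this assay, at which 1 of the 3 values shown sits). Compound 4 is therefore estimated at 100 nM, between 30 nM and 400 nM.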

Compound 4, half-maximal inhibitory concentration: 25.3 nM
The estimate for compound 4 lay 4.0-fold (0.60 log units) above the measured number; the measured number lies below the stated range.
By their numbers in this assay, from the lowest: compound 4; then compound 2; then compound 3. At a limit, above all of these: compound 1.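

In this assay, among the compounds shown here, the change on this ring nitrogen proves larger than the earlier compounds suggested: a 24-fold lower number from compound 3 to compound 4 (1.37 log units; beyond the scatter). Changing the ring and its alkyl group together moves the number far less, with 4-ethylpiperazin-1-yl in place of 4-methyl-1,4-diazepan-1-yl giving a 2.0-fold lower number from compound 2 to compound 4 (0.31 log units; beyond the scatter). Hydrogen in place of fluoro on an aromatic carbon gives an at least 39-fold lower number from compound 1 to compound 4 (1.59 log units; beyond the scatter), a step that starts from a limit of the assay: the limit of > 1000 nM in this assay, at which 1 of the 4 values shown sits.

Going by these compounds, it remains open how a bare hydrogen, a longer chain or a hydroxyethyl group on this ring nitrogen would compare with ethyl. On these data alone, the separate contributions of ring size and alkyl group also remain open, as the step between the two rings changes both at once.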